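The source may report more compounds than this note shows. Statements on the series, on what has been measured and on what is new or still open speak of the compounds shown alone.

Working notes on the series.

Three members of the shared core have been run in a functional assay on A549 cells (Homo sapiens) for antiproliferative activity, read by MTT assay, with a stated time of 48 h (on this read-out higher numbers stand for weaker inhibition and lower numbers for stronger inhibition), so far. Compound 1 `COc1ccc(/C=C/c2cc(OC)cc(OC)c2/C=C/C(=O)c2ccc(Cl)c(Cl)c2)cc1` gives 5.9 ug/mL in this assay. Compound 2 `COc1ccc(/C=C/c2cc(OC)cc(OC)c2/C=C/C(=O)c2cccc(Br)c2)cc1` gives 8.1 ug/mL. Compound 3 `COc1ccc(/C=C/c2cc(OC)cc(OC)c2/C=C/C(=O)c2ccccc2C)cc1` gives 5.9 ug/mL. Compound 2 carries the highest of the three numbers, but its steps to the others, a 1.4-fold higher number from compound 1 to compound 2 (0.14 log units; within the scatter) and a 1.4-fold lower number from compound 2 to compound 3 (0.14 log units; within the scatter), both lie within the scatter, so no order among the three can be read from these values. The third pairing, no change at the digits printed from compound 1 to compound 3 (within the scatter), is likewise within the scatter.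

Compound 4 `COc1ccc(/C=C/c2cc(OC)cc(OC)c2/C=C/C(=O)c2cccc(OC)c2)cc1` is the next member to be measured. It differs from compound 2 in one place: methoxy in place of bromo on an aromatic carbon. For the measured compounds named here, the steps that bear on this change are the three above, each of which swaps the aryl group attached to the carbonyl carbon, and none of them moved the number beyond the scatter. On that basis a step of no size beyond the scatter is expected from compound 2 to compound 4, in either direction.

Compound 4 is therefore expected to give about 7 ug/mL in this assay, with a range from 3.5 ug/mL to 14 ug/mL, an expected step of a 1.2-fold lower number from compound 2 to compound 4 (0.06 log units; within the scatter).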

Compound 4, half-maximal inhibitory concentration: 6.1 ug/mL
Compound 4: the middle estimate sits 1.1-fold (0.06 log units) above what was measured; the range from low to high includes it.
By their numbers in this assay, from the lowest: compounds 1, 3, 4 and 2 (each within the scatter of the next).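

For the compounds shown here, compound 4 gives the first step in which the place on the aromatic ring stays fixed and only the group on it changes: with bromo replaced by methoxy on the aromatic carbon meta to a large group, this assay shows a 1.3-fold lower number from compound 2 to compound 4 (0.12 log units; within the scatter) and so no shift beyond the scatter, even though the entering group adds a hydrogen-bond acceptor and one more heavy atom. The aryl group on the carbonyl also stays without a readable order across the series, as both a 1.0-fold higher number from compound 3 to compound 4 (0.01 log units; within the scatter) and a 1.0-fold higher number from compound 1 to compound 4 (0.01 log units; within the scatter) remain within the scatter, so 3-methoxyphenyl now joins 3,4-dichlorophenyl, 3-bromophenyl and 2-methylphenyl as groups that this read-out does not separate. No measurement at hand speaks to why this read-out stays so flat across these changes.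

Going by these compounds, whether an amine or a carboxylic acid on this same aromatic carbon would move the number beyond the scatter remains open, as does the effect of a longer chain such as butoxy there. The compounds shown also leave open whether the flat picture holds when the groups on the rest of the shared core are changed rather than the aryl group on the carbonyl.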